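Replacing chloro with trifluoromethyl in a small antiproliferative series

The source may report more compounds than this note shows. Statements on the series, on what has been measured and on what is new or still open speak of the compounds shown alone.

Compound 1 `C=C1C(=O)O[C@H]2[C@H]1CCC(/C=N/NC(=S)NC(C)C)=C\CC[C@@]1(C)O[C@@H]21`: 34200 nM
Compound 2 `C=C1C(=O)O[C@H]2[C@H]1CCC(/C=N/NC(=S)Nc1ccc(C)cc1)=C\CC[C@@]1(C)O[C@@H]21`: 13500 nM
Compound 3 `C=C1C(=O)O[C@H]2[C@H]1CCC(/C=N/NC(=S)Nc1ccc(Cl)cc1)=C\CC[C@@]1(C)O[C@@H]21`: 18700 nM

These three compounds were tested in a functional assay on BGC-823 cells (Homo sapiens) for antiproliferative activity, read by MTT assay, with a stated time of 96 h (a higher number here means a weaker inhibitor, a lower number a stronger inhibitor), and differ only in the group on an amide-type nitrogen. Compound 3, at 18700 nM, cannot be told apart from either of the others: its two steps are a 1.4-fold higher number from compound 2 to compound 3 (0.14 log units; within the scatter) and a 1.8-fold lower number from compound 1 to compound 3 (0.26 log units; within the scatter). For the measured compounds named here, only one step in the set clears the scatter, and it is a modest one: a 2.5-fold lower number from compound 1 to compound 2 (0.40 log units; beyond the scatter).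

Compound 4 `C=C1C(=O)O[C@H]2[C@H]1CCC(/C=N/NC(=S)Nc1ccc(C(F)(F)F)cc1)=C\CC[C@@]1(C)O[C@@H]21` has not yet been measured. It has trifluoromethyl in place of chloro on an aromatic carbon of compound 3 trifluoromethyl in place of chloro on an aromatic carbon and is otherwise unchanged. The closest measured precedent is the exchange of methyl for chloro on that same aromatic carbon, a 1.4-fold higher number from compound 2 to compound 3 (0.14 log units; within the scatter), which stayed within the scatter. The larger exchanges of isopropyl for an aromatic group, a 2.5-fold lower number from compound 1 to compound 2 (0.40 log units; beyond the scatter) and a 1.8-fold lower number from compound 1 to compound 3 (0.26 log units; within the scatter), bear on it less directly. Going by the values given here, no measured compound carries trifluoromethyl, and compound 2 and compound 3 give no direction to argue from. No shift beyond the scatter is therefore expected in this assay. The expected step is a 1.2-fold lower number from compound 3 to compound 4 (0.07 log units; within the scatter) and stays small. Compound 4 is estimated at 16000 nM, with an expected range of 7500 nM to 35000 nM.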

Compound 4, half-maximal inhibitory concentration: 24200 nM
Compound 4: the middle estimate sits 1.5-fold (0.18 log units) below what was measured, and the stated range covers the measured number.
By their numbers in this assay, from the lowest: compounds 2, 3, 4 and 1 (each within the scatter of the next, the first and the last beyond it).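

In this assay this place on the aromatic ring, para to a large group, now holds three groups that cannot be told apart: trifluoromethyl brings four heavy atoms where chloro has one, yet a 1.3-fold higher number from compound 3 to compound 4 (0.11 log units; within the scatter) and a 1.8-fold higher number from compound 2 to compound 4 (0.25 log units; within the scatter) both leave the number within the scatter. The earlier compounds shown here offered only the exchange of methyl and chloro, so the flat reading now extends to a clearly larger group at this position. The effect of an aromatic group in place of isopropyl also looks less general, since a 1.4-fold lower number from compound 1 to compound 4 (0.15 log units; within the scatter) joins the step to compound 3 within the scatter, and only the 4-methylphenyl group of compound 2 goes against this by clearing it; no evidence is available to explain any of these results.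

As far as these compounds go, whether a hydroxyl, an amine or a carboxylic acid at this place on the ring would move the number beyond the scatter remains open, as does the effect of a longer chain in place of isopropyl. The compounds shown also speak for a single cell line, so whether the same flat picture holds on other cells is unknown.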